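The compounds below may be only part of what the source reports. "The series", "measured", "known", "first", "only" and "open" are said of these compounds alone.

Three agonists have been read in a functional assay on CHO cells for agonist activity at Free fatty acid receptor 1 (Homo sapiens), read by FLIPR and calcium flux; on this read-out higher numbers stand for an effect only at larger amounts of compound and lower numbers for an effect already at smaller amounts. Compound 1 `CC#CC(c1ccc(OCc2ccccc2)cc1)C1OC(=O)NC1=O` gives 954 nM, compound 2 `O=C(O)C(Cc1ccc(Oc2ccc(C(F)(F)F)cc2Cl)cc1)C(=O)O` gives 970 nM, and compound 3 `CC#CC(CC(=O)O)c1ccc(Oc2ccc(C#N)cc2Br)cc1` gives 85 nM. Compound 2 thus has the highest number of the three; its value and that of compound 1 lie within the scatter of each other, whereas compound 3 sits clearly lower, beyond the scatter. Compound 4 `O=C(O)CCc1ccc(Oc2ccc(C(F)(F)F)cc2Cl)cc1` is not yet measured. It differs from compound 2 by hydrogen in place of carboxy on a saturated chain carbon bound to a carbonyl carbon and a saturated chain carbon, so that the dicarboxymethyl becomes carboxymethyl and the 2,2-dicarboxyethyl a 2-carboxyethyl. Within the data shown here, no measured pair shows this change, so the expected step from compound 2 to compound 4 in this assay, a 2.4-fold lower number from compound 2 to compound 4 (0.38 log units; beyond the scatter), is a modest move toward a lower number, with wide uncertainty. Compound 4 is accordingly estimated at 400 nM, within 100 nM to 2000 nM.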

Compound 4, half-maximal effective concentration: 686 nM
The estimate for compound 4 lay 1.7-fold (0.23 log units) below the measured number; low and high end bracket the measured number.
By their numbers in this assay, from the lowest: compound 3; then compounds 4, 1 and 2 (each within the scatter of the next).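

In this assay, hydrogen in place of carboxy on this saturated chain carbon gives a 1.4-fold lower number from compound 2 to compound 4 (0.15 log units; within the scatter), the first step read at this position. With this core, the dicarboxymethyl and carboxymethyl forms therefore cannot be told apart, so the second carboxy shows no measurable contribution to this read-out. Nothing available explains this result. The compounds shown leave open how a methyl or a hydroxyl on this same carbon would read, and how a longer chain carrying the carboxy would read. They also leave open whether this step would hold on the core of compound 3.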